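This account rests on a few compounds, and the source may have more. Where it says the series, first, only, none or still open, it means among the compounds named here.

Compound 3 `C=CC[C@H]1C[C@]2([C@@H](C)Cc3ccc(OC)nc3)OCOC2=CC1=O` gives 330 nM in a functional assay on NCI-H460 cells (Homo sapiens) for antiproliferative activity, with a stated time of 72 h (a higher number here means a weaker inhibitor, a lower number a stronger inhibitor), the higher of the two numbers reported. Compound 1 `C=CC[C@H]1C[C@]2([C@@H](C)Cc3ccc(OC)cc3)OCOC2=CC1=O` gives 90 nM in this assay, and the step of a 3.7-fold higher number from compound 1 to compound 3 (0.56 log units; beyond the scatter) records what the change of aromatic ring cost. Compound 2 `C=CC[C@H]1C[C@]2([C@@H](C)Cc3ccc(O)cc3)OCOC2=CC1=O` reaches only the assay limit, > 20000 nM, in this assay. That limit is one of the values behind (the limit of > 20000 nM in this assay, at which 1 of the 3 values shown sits). The steps of an at least 220-fold higher number from compound 1 to compound 2 (2.34 log units; beyond the scatter) and an at least 60-fold lower number from compound 2 to compound 3 (1.78 log units; beyond the scatter) both turn on the presence of the methyl on the aromatic oxygen, which compound 4 keeps.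

Compound 4 `C=CC[C@H]1C[C@]2([C@@H](C)Cc3cnc(OC)c(OC)c3)OCOC2=CC1=O` has not been measured; it differs from compound 3 by methoxy in place of hydrogen on an aromatic carbon. For the measured compounds named here, no measured step adds a group to this ring, so the large steps around compound 2 do not bear directly on it, and only the modest step from compound 1 to compound 3 shows how this aromatic ring tolerates change. Compound 4 is therefore expected to show a step of about a 1.5-fold higher number from compound 3 to compound 4 (0.18 log units; within the scatter), at most modestly weaker. Compound 4 is estimated at 500 nM in this assay, within 150 nM to 2500 nM.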

Compound 4, half-maximal inhibitory concentration: > 20000 nM
Compound 4: a limit, no number; the forecaster's own chance of this, stated with the estimate: 5%; middle value at least 40-fold (1.60 log units) from the limit.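

For the compounds shown here, this is the first measured change that adds a group to this aromatic ring, and the outcome is far larger than the ring swap suggested. The step of a 3.7-fold higher number from compound 1 to compound 3 (0.56 log units; beyond the scatter) was modest, whereas the single added methoxy, on an aromatic carbon ortho to a methoxy group and two atoms from the ring nitrogen, gives an at least 60-fold higher number from compound 3 to compound 4 (1.78 log units; beyond the scatter). As far as these compounds go, the result for compound 4 in this assay is a limit and not a number, so the true size of this loss stays unknown, and it is the second such result: the limit of > 20000 nM in this assay, at which 2 of the 4 values shown sit.

The compounds shown leave open whether a smaller group, such as fluorine or methyl, would be accepted on this carbon. They also leave open whether an added methoxy would cost as much on the benzene ring of compound 1.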